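Swapping Nitro for Propyl on a Sulfonate Ester

A few compounds are considered here, and "the series" means these few. Any claim that something is new, unique, unknown or untested is made for them only; others in the source may bear on it.

Of the compounds shown here, three have so far been tested in an assay for inhibition of beta-glucuronidase (Bos taurus), read by spectrophotometry, with a stated time of 30 min; on this read-out higher numbers stand for weaker inhibition and lower numbers for stronger inhibition. Compound 1 `CCCCCCCCS(=O)(=O)Nc1cnc2ccccc2c1` gives 75100 nM. Compound 2 `O=[N+]([O-])c1ccc(S(=O)(=O)Oc2cccc3cccnc23)cc1` gives 15400 nM, the second highest of the three numbers. Compound 3 `O=[N+]([O-])c1ccccc1S(=O)(=O)Oc1cccc2cccnc12` gives 6400 nM, a lower number than compound 2 by a gap beyond the usual scatter, while compound 1 sits higher than compound 2, also beyond the scatter. Compound 4 `CCCc1ccc(S(=O)(=O)Oc2cccc3cccnc23)cc1` has not yet been measured. It differs from compound 2 in one place: propyl in place of nitro on an aromatic carbon. Among the compounds with values here, no measured pair shows this same change, so nothing is known about its effect; a step of modest size is expected, in either direction, probably not far beyond the scatter. For compound 4 in this assay a value of 18000 nM is estimated, within a range of 5000 nM to 60000 nM. That estimate means an expected step of a 1.2-fold higher number from compound 2 to compound 4 (0.07 log units; within the scatter).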

Compound 4, half-maximal inhibitory concentration: 84400 nM
For compound 4 the middle estimate is 4.7-fold (0.67 log units) below the measured one, and the stated range ends below it.
By their numbers in this assay, from the lowest: compound 3; then compound 2; then compounds 1 and 4 (each within the scatter of the next).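

On the aromatic carbon para to a large group, the choice of group clearly matters: in this assay, propyl in place of nitro gives a 5.5-fold higher number from compound 2 to compound 4 (0.74 log units; beyond the scatter) and so weakens inhibition. The two groups have the same count of heavy atoms but differ in hydrogen-bond acceptors, so heavy-atom count alone does not set the value here. Nothing at hand explains this step. On these data alone, whether an amine or a carboxylic acid on this carbon would give a number nearer compound 2 or compound 4 remains open, as does the effect of a longer chain.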